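The source may hold more compounds than are shown below. What is called first, only, known or untested is meant among the compounds shown, and "the series" means these compounds.

Measured compounds:
compound 1, `COc1cc(NC(C)CCCNC(=O)NNC(=O)Nc2cc(C(F)(F)F)cc(C(F)(F)F)c2)c2ncccc2c1`, 18000 nM
compound 2, `COc1cc(NC(C)CCCNC(=O)NNC(=O)Nc2ccc(O)cc2)c2ncccc2c1`, 95000 nM
compound 3, `COc1cc(NC(C)CCCNC(=O)NNC(=O)Nc2ccc(F)cc2)c2ncccc2c1`, 104000 nM

In a functional assay on L1210 cells (Mus musculus) for inhibition, read by MTT assay, with a stated time of 72 h (on this read-out higher numbers stand for weaker inhibition and lower numbers for stronger inhibition), compound 2 gives 95000 nM, the second highest of the three numbers. Its nearest neighbour is compound 3, which gives 104000 nM; a 1.1-fold higher number from compound 2 to compound 3 (0.04 log units; within the scatter). Furthest from it is compound 1, whose 18000 nM is lower by a gap beyond the scatter.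

Compound 4, `COc1cc(NC(C)CCCNC(=O)Nc2cccc(C(F)(F)F)c2)c2ncccc2c1`, has not been measured. It differs from compound 2 in one place: 3-(trifluoromethyl)phenyl in place of ((4-hydroxyphenyl)carbamoyl)amino on an amide-type nitrogen. Going by the values given here, no measured step covers this change. Among the compounds with values here, the single measured step, a 1.1-fold higher number from compound 2 to compound 3 (0.04 log units; within the scatter), swaps one small group on the aromatic ring and leaves everything else untouched, and it lies within the scatter. Within the data shown here, the only bearing the numbers offer is that compound 1, which carries trifluoromethyl groups on its aromatic ring, gives 18000 nM, while compound 2 gives 95000 nM. Among the measured compounds shown here, on that basis compound 4 is expected to show a lower number than compound 2, the expected step being a 3.2-fold lower number from compound 2 to compound 4 (0.50 log units; beyond the scatter), though the loss of the carbamoylamino link has no measured counterpart and the range is kept wide. Compound 4 is estimated at 30000 nM, with a range from 8000 nM to 120000 nM.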

Compound 4, half-maximal inhibitory concentration: 9200 nM
Beside the measured number, compound 4's estimate is 3.3-fold (0.51 log units) above it; low and high end bracket the measured number.
By their numbers in this assay, from the lowest: compounds 4 and 1 (each within the scatter of the next); then compounds 2 and 3 (each within the scatter of the next).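

In this assay, putting 3-(trifluoromethyl)phenyl in place of ((4-hydroxyphenyl)carbamoyl)amino on the amide-type nitrogen gives a large step (a 10-fold lower number from compound 2 to compound 4 (1.01 log units; beyond the scatter)), and the same exchange starting from ((4-fluorophenyl)carbamoyl)amino gives a large step as well (an 11-fold lower number from compound 3 to compound 4 (1.05 log units; beyond the scatter)). The earlier step (a 1.1-fold higher number from compound 2 to compound 3 (0.04 log units; within the scatter)) had shown only that fluoro in place of hydroxy on the aromatic carbon leaves the number within the scatter, whereas these two steps show that this position on the amide-type nitrogen can move the number well beyond it, in the direction of stronger inhibition, from either starting group. No measurement given here bears on why this exchange has such an effect.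

The exchange removes the carbamoylamino link and changes the ring substituent at once, so the compounds shown cannot separate the two; a plain phenyl or a 4-hydroxyphenyl group set directly on the same nitrogen would divide that step into its parts. Going by these compounds, whether other groups on that ring, such as a nitrile or a methoxy, would serve as trifluoromethyl does here also stays open.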